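The source may report more compounds than this note shows. Statements on the series, on what has been measured and on what is new or still open speak of the compounds shown alone.

Working notes on the series in an ADME assay on HEK293 cells (Homo sapiens) for cytotoxicity, read by CellTiter-Glo and resazurin assay, with a stated time of 72 h; a higher number here means that more compound is needed for the effect, a lower number that less compound is needed. Compound 3 `CCOC(=O)CCCCCOc1cccc(CN(C(=O)c2ccc(-c3cccnc3)cc2)C(C)C)c1` gives only a limit here, > 26000 nM. Compound 2 `CCOC(=O)CCCCCOc1cccc(CN(C(=O)c2ccc(-c3ccncc3)cc2)C(C)C)c1` likewise gives only a limit, > 26000 nM. The step that the two limits leave unreadable from compound 2 to compound 3 is therefore unreadable. Compound 1 `CC(=O)c1cccc(-c2ccc(C(=O)N(Cc3cccc(OCCCCCC(=O)O)c3)C(C)C)cc2)c1`, which already carries the 3-acetylphenyl group, gives a limit as well, > 26000 nM. Among the compounds with values here, every number in the set sits at the limit of > 26000 nM in this assay, at which 3 of the 3 values shown sit, so no step between measured compounds has a readable size.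

Compound 4 `CCOC(=O)CCCCCOc1cccc(CN(C(=O)c2ccc(-c3cccc(C(C)=O)c3)cc2)C(C)C)c1` differs from compound 3 by 3-acetylphenyl in place of pyridin-3-yl on an aromatic carbon. Within the data shown here, no measured step bears directly on this change, and the single step in this assay sits between two limits. Among the measured compounds shown here, the only guide is that compound 1, carrying the same 3-acetylphenyl group, stays at the limit in this assay, > 26000 nM. Compound 4 is thus expected to remain at the limit as well, with an estimate of 30000 nM and a range from 15000 nM to 100000 nM. The expected step that the limit leaves unreadable from compound 3 to compound 4 is none beyond the usual scatter.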

Compound 4, half-maximal effective concentration: > 26000 nM
Compound 4: only a limit was reported; the forecaster's own chance of this, stated with the estimate: 85%; the middle value does not contradict the limit.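

Compound 4 gives only a limit, > 26000 nM and so adds no readable step against compound 1, compound 2 or compound 3: the limit of > 26000 nM in this assay, at which 4 of the 4 values shown sit.

The compounds shown leave open whether any of these changes alters the value in this assay at all, with no number yet readable for any of them.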